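Trimming the amine substituent from isobutyl to propyl

The source may report more compounds than this note shows. Statements on the series, on what has been measured and on what is new or still open speak of the compounds shown alone.

Measured compounds and their values:
- Compound 1, `CCN1CCc2c(sc(NC(=O)Nc3ccc(Br)cc3)c2C(N)=O)C1`: 3130 nM
- Compound 2, `CC(C)CN1CCc2c(sc(NC(=O)Nc3ccc(Cl)cc3)c2C(N)=O)C1`: 4510 nM
- Compound 3, `C[N+]1(CC2CCC2)CCc2c(sc(NC(=O)Nc3ccc(Cl)cc3)c2C(N)=O)C1`: 210 nM

All three share one core and differ mainly in the group carried on the ring nitrogen of the saturated part. In a functional assay (strain AB) with Danio rerio as the target, read by microscopy, with a stated time of 1 h (a higher number here means that more compound is needed for the effect, a lower number that less compound is needed), compound 2 gives 4510 nM, the highest of the three numbers. Compound 1 sits close to it, a gap that is within the usual scatter of this kind of measurement, so the two cannot be ranked against each other. Compound 3, the charged compound, stands far lower, and that gap lies well beyond the scatter.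

Compound 4 is `CCCN1CCc2c(sc(NC(=O)Nc3ccc(Cl)cc3)c2C(N)=O)C1`. It has not yet been measured in this assay. It is compound 2 with one change: hydrogen in place of methyl on a saturated chain carbon bound to two saturated chain carbons. Nothing else moves, so only a small piece of the chain is cut away.

Among the measured compounds shown here, no measured pair shows this exact change, so an expectation must rest on the numbers above. Compound 1, which carries a shorter chain on the same nitrogen, gives 3130 nM, a value within the scatter of compound 2. Shortening the chain by one carbon is therefore expected to produce little or no movement beyond the scatter, with the estimated step of a 1.3-fold lower number from compound 2 to compound 4 (0.10 log units; within the scatter) pointing slightly toward a lower number. For compound 4 the expected value in this assay is 3600 nM, within a range from 1500 nM to 9000 nM.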

Compound 4, half-maximal effective concentration: 3500 nM
Compound 4: middle estimate off by 1.0-fold (0.01 log units), on the high side, within the range that was stated.
By their numbers in this assay, from the lowest: compound 3; then compounds 1, 4 and 2 (each within the scatter of the next).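

Here, for the first time, a single change can be read on its own: in this assay, hydrogen in place of methyl on a saturated chain carbon bound to two saturated chain carbons gives a 1.3-fold lower number from compound 2 to compound 4 (0.11 log units; within the scatter) and so stays inside what repeated measurements of this kind would show anyway. Trimming isobutyl to propyl therefore takes away the branching methyl without any reading that can be told apart from scatter, so in this pair the methyl makes no detectable difference to the concentration needed for the effect. No measured property or other outside data bears on this result, so nothing can be said about what lies behind it.

Still open, from the compounds shown here alone, is whether a longer chain such as butyl, or a chain ending in an amine or a carboxylic acid, would leave the number at this level or move it beyond the scatter. Compound 3, at 210 nM, differs from compound 4 in more than one place, so its value cannot yet be assigned to any one structural change.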